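This account rests on a few compounds, and the source may have more. Where it says the series, first, only, none or still open, it means among the compounds named here.

Of the compounds shown here, two sharing one core have so far been tested in a functional assay on CH1 cells (Homo sapiens) for inhibition, read by sulforhodamine B assay, with a stated time of 96 h; a higher number here means a weaker inhibitor of growth, a lower number a stronger inhibitor of growth. Compound 1 `CC[C@@H](Nc1nc(NCc2ccccn2)c2ncn(C(C)C)c2n1)C(C)(C)O` gives > 50000 nM, which is a limit of the assay and not a number. Going by the values given here, compound 2 `CCC(O)[C@H](CC)Nc1nc(NCc2ccccn2)c2ncn(C(C)C)c2n1` gives 26000 nM, the only actual number available, so it has no measured neighbour to be ranked against with any precision.

Compound 3 `CC[C@H](Nc1nc(NCc2ccccn2)c2ncn(C(C)C)c2n1)C(O)C(C)(C)C` is the next to be read. Its difference from compound 2 is tert-butyl in place of ethyl on a saturated chain carbon bound to an oxygen on a saturated carbon and a saturated chain carbon, which turns the 1-ethyl-2-hydroxybutyl group into 1-ethyl-2-hydroxy-3,3-dimethylbutyl. Among the compounds with values here, the one measured step bearing on this is an at least 1.9-fold lower number from compound 1 to compound 2 (0.28 log units; that floor lies within the scatter), and it alters the same side chain. That step has only a floor for its size, so it gives weak guidance, though it suggests that added branching in this chain does not favour growth inhibition. The expected change is a 1.2-fold higher number from compound 2 to compound 3 (0.09 log units; within the scatter), a modest move toward a weaker inhibitor of growth that may not clear the usual scatter. For compound 3 the estimated value in this assay is 32000 nM, with an expected range of 12000 nM to 65000 nM.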

Compound 3, concentration for 50% growth inhibition: 47000 nM
Beside the measured number, compound 3's estimate is 1.5-fold (0.17 log units) below it, and the stated range covers the measured number.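

In this assay, going by these compounds alone, exchanging ethyl for tert-butyl on this saturated chain carbon bound to an oxygen gives the first step between two actual numbers, a 1.8-fold higher number from compound 2 to compound 3 (0.26 log units; within the scatter), so the exchange of a group of 2 heavy atoms for one of 4 does not separate the two compounds. The step from the limit compound reads an at least 1.0-fold lower number from compound 1 to compound 3 (0.02 log units; that floor lies within the scatter); it is only a floor, so it does not rank that pair, and the hint from the earlier floor that branching in this chain disfavours growth inhibition gains no support from a measured difference. Compound 1 remains a limit and not a number, which restricts what can be read in this series: the limit of > 50000 nM in this assay, at which 1 of the 3 values shown sits.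

The compounds shown leave open whether any group at this place can move the number beyond the scatter, since only ethyl and tert-butyl have been compared here in actual numbers. A phenyl ring, a longer chain or an amine on this same carbon could answer that, and each would show whether growth inhibition responds to this position at all.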